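The compounds below may be only part of what the source reports. "The series", "measured", "known", "first", "only" and "open" are said of these compounds alone.

Compound 1 `Clc1cccc(CSc2nnc(-c3ccncc3)n2-c2ccccc2)c1` — 10500 nM
Compound 2 `O=[N+]([O-])c1cccc(CSc2nnc(-c3ccncc3)n2-c2ccccc2)c1` — 18300 nM
Compound 3 `COc1ccc(/C=N/NC(=O)CSc2nnc(-c3ccncc3)n2-c2ccccc2)cc1` — 23700 nM

All three were tested in a functional assay on MCF7 cells (Homo sapiens) for inhibition, read by MTT assay, with a stated time of 48 h; a lower number here means a stronger inhibitor, a higher number a weaker inhibitor. Of the three numbers, compound 3 carries the largest, but its gap to compound 2 is within the usual scatter, so those two cannot be told apart; only compound 1 sits clearly lower than compound 3.

Compound 4 `O=C(CSc1nnc(-c2ccncc2)n1-c1ccccc1)N/N=C/c1ccccc1F` has not yet been measured in this assay. It differs from compound 3 in one place: 2-fluorophenyl in place of 4-methoxyphenyl on a carbon with a double bond to nitrogen. Going by the values given here, only one measured step exists among the three compounds, a 1.7-fold higher number from compound 1 to compound 2 (0.24 log units; within the scatter), a swap of one substituent for another on an aromatic ring at a different part of the shared core, and it stayed within the scatter. Among the compounds with values here, no measured pair changes the aryl group on the carbon double-bonded to nitrogen, so nothing directly tells how this swap will play out. Within the data shown here, with the one step available being small, the expectation for compound 4 is a step of a 1.2-fold lower number from compound 3 to compound 4 (0.07 log units; within the scatter), that is, nothing beyond the scatter. Compound 4 is therefore estimated at 20000 nM in this assay, with a range from 8000 nM to 50000 nM.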

Compound 4, half-maximal inhibitory concentration: 22400 nM
Beside the measured number, compound 4's estimate is 1.1-fold (0.05 log units) below it; the measured number falls inside the stated range.
By their numbers in this assay, from the lowest: compounds 1, 2, 4 and 3 (each within the scatter of the next, the first and the last beyond it).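

In this assay, going by these compounds alone, putting 2-fluorophenyl in place of 4-methoxyphenyl on a carbon with a double bond to nitrogen gives a 1.1-fold lower number from compound 3 to compound 4 (0.02 log units; within the scatter), the first measured step at this position, and it leaves the two compounds impossible to tell apart. The exchange is not a trivial one on paper: the methoxy oxygen goes, a fluorine comes in, the substituent's place on the phenyl ring changes, and the count of hydrogen-bond acceptors in the group drops from one to none, yet in this single pair the number stays within the scatter. Nothing available explains why this exchange leaves the number where it is, and no outside measurement bears on the result.

From the compounds shown here alone, both groups seen here are phenyl rings carrying one substituent, so it remains open whether something of a different kind on this carbon, such as an amine, a carboxylic acid or a longer chain, would give a step beyond the scatter. Going by these compounds, it is also open whether other substituents on the phenyl ring, such as a hydroxyl group or a nitrile, would stay as close to compound 3 as compound 4 does.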